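The source may hold more compounds than are shown below. What is called first, only, known or untested is meant among the compounds shown, and "the series" means these compounds.

Measured so far in a functional assay on OVCAR-8 cells (Homo sapiens) for antiproliferative activity; on this read-out lower numbers stand for stronger inhibition and higher numbers for weaker inhibition:
compound 1 `Cn1ncc(Cl)c1-c1cc(C(=O)N[C@H]2CNCC[C@@H]2c2ccc(C(F)(F)F)cc2)oc1Cl` gives 900 nM
compound 2 `Cn1ncc(Cl)c1-c1cc(C(=O)N[C@@H]2CN[C@H](CCO)C[C@H]2c2ccc(F)c(F)c2)oc1Cl` gives 460 nM
compound 3 `C=CC[C@@H]1C[C@@H](c2ccc(Cl)c(Cl)c2)[C@H](NC(=O)c2cc(-c3c(Cl)cnn3C)c(Cl)o2)CN1` gives 990 nM

Compound 3 has the highest of the three numbers. Its gap to compound 1 is within the scatter, so the two cannot be ordered on this assay. Compound 2 sits beyond the scatter on the lower side of compound 3; compound 2 is the one of the three whose saturated ring carries a further chain ending in a hydroxyl.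

Compound 4 `Cn1ncc(Cl)c1-c1cc(C(=O)N[C@@H]2CN[C@H](CC(=O)NCCO)C[C@H]2c2ccc(Cl)c(Cl)c2)oc1Cl` is not yet measured. It keeps the shared core of compound 3 and the same aryl group, and differs from compound 3 in one place: (2-hydroxyethyl)carbamoyl in place of vinyl on a saturated chain carbon bound to a saturated ring carbon.

Within the data shown here, no pair of measured compounds differs in exactly one place, so no measured step can be read off for this kind of change. Among the measured numbers, the chain-bearing compound 2 gives 460 nM while compound 3 gives 990 nM; this is the only hint available for what a longer chain on that ring carbon may do. The step is expected to be small to moderate, toward a lower number, and possibly no more than the scatter; an estimated step of a 1.7-fold lower number from compound 3 to compound 4 (0.22 log units; within the scatter) is taken. Compound 4 is therefore expected at 600 nM, with a range from 250 nM to 1500 nM.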

Compound 4, half-maximal inhibitory concentration: 1450 nM
For compound 4 the middle estimate is 2.4-fold (0.38 log units) below the measured one; low and high end bracket the measured number.
By their numbers in this assay, from the lowest: compounds 2, 1, 3 and 4 (each within the scatter of the next, the first and the last beyond it).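

In this assay, (2-hydroxyethyl)carbamoyl in place of vinyl on a saturated chain carbon bound to a saturated ring carbon gives a 1.5-fold higher number from compound 3 to compound 4 (0.17 log units; within the scatter), so this first readable step at the position does not separate the two compounds. The position thus takes a group of 6 heavy atoms with 2 hydrogen-bond donors and 2 hydrogen-bond acceptors in place of one of 2 heavy atoms with neither, and the read-out in this assay gives no measurable sign of either a gain or a loss. No accompanying measurement bears on this step, and the data offer no explanation for it.

From the compounds shown here alone, it remains open whether a primary amine, a carboxylic acid or a longer chain on the same carbon would give a step beyond the scatter, and so whether this position responds to any change at all in this assay. Also open, going by these compounds, is whether the same change would give a similar step with the aryl groups carried by compound 1 and compound 2, as the step is read on a single aryl group only.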